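The source may hold more compounds than are shown below. What is called first, only, known or untested is meant among the compounds shown, and "the series" means these compounds.

Compound 1, `Cc1cccc(-c2noc([C@@H](C)NC(=O)c3cc(C4CC4)nn3C)n2)c1`, gives 3310 nM in an assay on T-REx-293 cells for inhibition of potassium channel subfamily T member 1 (Homo sapiens), read by patch clamp; on this read-out higher numbers stand for weaker inhibition and lower numbers for stronger inhibition.
Compound 2, `C[C@H](NC(=O)c1cc(C(F)(F)F)nn1C)c1nc(-c2cccnc2)no1`, gives 11800 nM in this assay.

Of these two numbers, compound 2 holds the higher one, so it is the weaker inhibitor, and the gap to compound 1 lies beyond the usual scatter. Compound 3, `COCc1cc(-c2noc([C@H](C)NC(=O)c3cc(C(F)(F)F)nn3C)n2)ccn1`, carries 2-(methoxymethyl)pyridin-4-yl in place of pyridin-3-yl on an aromatic carbon while the rest of the shared core stays as in compound 2. Among the compounds with values here, no measured pair shows what this change does, so the direction is open; a modest step is expected, from compound 2 to compound 3 of a 2.0-fold lower number from compound 2 to compound 3 (0.29 log units; within the scatter). Compound 3 is estimated at 6000 nM, within a range of 1500 nM to 25000 nM.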

Compound 3, half-maximal inhibitory concentration: 322 nM
Compound 3: the middle estimate sits 19-fold (1.27 log units) above what was measured; measured number outside the range, below it.
By their numbers in this assay, from the lowest: compound 3; then compound 1; then compound 2.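

Changing pyridin-3-yl to 2-(methoxymethyl)pyridin-4-yl on this aromatic carbon gives a 37-fold lower number from compound 2 to compound 3 (1.56 log units; beyond the scatter) in this assay and makes compound 3 the strongest inhibitor of the three. This shows that the group at this position can strongly change inhibition while the rest of the shared core stays the same. Nothing available explains the gain.

Within the data shown here, the single step leaves open whether it comes from the pyridin-4-yl ring or from the methoxymethyl chain. Plain pyridin-4-yl would separate the two, and an aminomethyl or longer ethoxymethyl chain would test what the chain tolerates.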